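The source may report more compounds than this note shows. Statements on the series, on what has been measured and on what is new or still open speak of the compounds shown alone.

Compound 1 `C=CCn1c(=O)/c(=C\c2cccc(F)c2)[nH]c(=O)/c1=C\c1ccccc1OC` holds the lower of the two numbers measured in a functional assay on K562 cells (Homo sapiens) for cytotoxicity, read by CCK-8 assay, with a stated time of 72 h (on this read-out higher numbers stand for weaker inhibition and lower numbers for stronger inhibition), where compound 1 gives 4100 nM. Compound 2 `C=CCn1c(=O)/c(=C\c2ccccc2OC)[nH]c(=O)/c1=C\c1ccccc1OC` gives 7400 nM in this assay, and the step of a 1.8-fold higher number from compound 1 to compound 2 (0.26 log units; within the scatter) stays within the scatter. Compound 3 `C=CCn1c(=O)/c(=C\c2ccc(F)c(Br)c2)[nH]c(=O)/c1=C\c1ccccc1OC` is reported in this assay as "not active" (no number reported), with no number given. The unmeasured compound 4 `C=CCn1c(=O)/c(=C\c2cccc(C)c2)[nH]c(=O)/c1=C\c1ccccc1OC` differs from compound 1 by methyl in place of fluoro on an aromatic carbon. Among the measured compounds shown here, no measured step exchanges fluoro for methyl; the only measured step put 2-methoxyphenyl in place of 3-fluorophenyl and stayed within the scatter, while compound 3 carries a different change on that ring and came back without a number. The expected step is therefore none beyond the scatter, a 1.1-fold higher number from compound 1 to compound 4 (0.04 log units; within the scatter). Compound 4 is estimated at 4500 nM, expected between 2000 nM and 10000 nM.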

Compound 4, half-maximal inhibitory concentration: 8800 nM
The estimate for compound 4 lay 2.0-fold (0.29 log units) below the measured number, within the range that was stated.
By their numbers in this assay, from the lowest: compounds 1, 2 and 4 (each within the scatter of the next, the first and the last beyond it).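

In this assay, among the compounds shown here, methyl in place of fluoro on the aromatic carbon gives a 2.1-fold higher number from compound 1 to compound 4 (0.33 log units; beyond the scatter) and is the first step here to pass the scatter, though only modestly. So this position does respond to a change of a single heavy atom, with 3-fluorophenyl holding the lower number. By contrast, a 1.2-fold higher number from compound 2 to compound 4 (0.08 log units; within the scatter) stays within the scatter, leaving 3-methylphenyl and 2-methoxyphenyl indistinguishable. The compounds shown leave open how an amine, a carboxylic acid or a longer chain such as propyl would read at this position. Nothing shown accounts for the step from fluoro to methyl.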